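The source may report more compounds than this note shows. Statements on the series, on what has been measured and on what is new or still open speak of the compounds shown alone.

Three compounds share one core and differ only in the aryl group hanging from the exocyclic double bond. Compound 1 `O=C1/C(=C\c2ccc(O)cc2)c2ccccc2N1c1c(Cl)cccc1Cl` was tested in a functional assay on MOLT-4 cells (Homo sapiens) for cytotoxicity, read by MTT assay, with a stated time of 72 h (a lower number here means that less compound is needed, a higher number that more compound is needed for the effect), and gives "not determined" (no result reported), and compound 3 `CN(C)c1ccc(/C=C2\C(=O)N(c3c(Cl)cccc3Cl)c3ccccc32)cc1` likewise gives "not determined" (no result reported), so compound 3 stands with no number at all on this read-out, one of two entries in that position. Among the measured compounds shown here, the only measured value comes from compound 2 `O=C1/C(=C\c2cccc(Br)c2)c2ccccc2N1c1c(Cl)cccc1Cl`, which in this assay gives 7 ug/mL.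

The change from compound 3 to compound 4 `O=C1/C(=C\c2ccccc2[N+](=O)[O-])c2ccccc2N1c1c(Cl)cccc1Cl` is 2-nitrophenyl in place of 4-(dimethylamino)phenyl on a double-bonded chain carbon bound to a double-bonded ring carbon. Compound 4 keeps everything else, including the dichlorophenyl substituent on the ring nitrogen that all four compounds carry.

With no number for compound 3, the size and direction of the step in this assay cannot be anchored to a starting point. For the measured compounds named here, the one firm number available, compound 2 at 7 ug/mL, comes from a closely related compound, and compound 4 is therefore expected to land in the same general region rather than far from it. Compound 4 is estimated to give about 8 ug/mL in this assay, most likely between 3 ug/mL and 25 ug/mL.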

Compound 4, concentration for half-maximal effect: 6 ug/mL
Estimate against measurement, compound 4: 1.3-fold (0.12 log units) above, and the stated range covers the measured number.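

In this assay, this place on a double-bonded chain carbon bound to a double-bonded ring carbon now has two measured groups, and swapping 3-bromophenyl for 2-nitrophenyl gives a 1.2-fold lower number from compound 2 to compound 4 (0.07 log units; within the scatter). Among the compounds shown here, the earlier compounds offered only one number and so no comparison; this pair shows that two groups with different atoms and different numbering in their names cannot be told apart on this read-out. No measurement shown here bears on why the two compounds read alike.

As far as these compounds go, the steps involving compound 1 and compound 3 cannot be read, so it remains open whether 4-hydroxyphenyl or 4-(dimethylamino)phenyl at this place would give a number close to those of compound 2 and compound 4. Also open, from the compounds shown here alone, is how a carboxylic acid on the phenyl ring or a pyridine ring in place of it would read, and whether an unsubstituted phenyl could replace the dichlorophenyl on the ring nitrogen that all four compounds carry.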